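A few compounds are considered here, and "the series" means these few. Any claim that something is new, unique, unknown or untested is made for them only; others in the source may bear on it.

Measured in a functional assay on NCI-H460 cells (Homo sapiens) for cytotoxicity, read by MTT assay, with a stated time of 72 h; on this read-out lower numbers stand for stronger inhibition and higher numbers for weaker inhibition:
Compound 1 `CN(C)CCn1cnnc1-c1cc(Oc2ccc(NC(=O)N/N=C/c3c(Cl)cccc3Cl)cc2F)ccn1` gives 350 nM.
Compound 2 `COc1ccc(OC)c(/C=N/NC(=O)Nc2ccc(Oc3ccnc(-c4nncn4CCN(C)C)c3)c(F)c2)c1` gives 2930 nM.
Compound 3 `CN(C)CCn1cnnc1-c1cc(Oc2ccc(NC(=O)N/N=C/c3ccc(O)c(Br)c3)cc2F)ccn1` gives 430 nM.

Compound 3 holds the second highest of the three numbers. Its nearest neighbour is compound 1, separated by a 1.2-fold higher number from compound 1 to compound 3 (0.09 log units; within the scatter), so the two are indistinguishable here. Its furthest is compound 2, which sits well apart: a 6.8-fold lower number from compound 2 to compound 3 (0.83 log units; beyond the scatter). The only clearly resolved movement in the set is from the 2,6-dichlorophenyl to the 2,5-dimethoxyphenyl, an 8.4-fold higher number from compound 1 to compound 2 (0.92 log units; beyond the scatter).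

Compound 4 `CN(C)CCn1cnnc1-c1cc(Oc2ccc(NC(=O)N/N=C/c3ccc(Cl)cc3)cc2F)ccn1` differs from compound 3 in one place: 4-chlorophenyl in place of 3-bromo-4-hydroxyphenyl on a carbon with a double bond to nitrogen. Both steps that touch this position bear on it. The swap between two halogenated aryl groups, compound 1 to compound 3, stayed within the scatter; only the dimethoxy variant moved the number upward. A 4-chlorophenyl resembles the halogenated aryls of compound 1 and compound 3 more than the dimethoxy aryl of compound 2, so no step beyond the scatter is expected in this assay.

Compound 4 is therefore estimated at 450 nM, with a range from 200 nM to 1100 nM; this corresponds to an expected step of a 1.0-fold higher number from compound 3 to compound 4 (0.02 log units; within the scatter).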

Compound 4, half-maximal inhibitory concentration: 320 nM
Beside the measured number, compound 4's estimate is 1.4-fold (0.15 log units) above it, within the range that was stated.
By their numbers in this assay, from the lowest: compounds 4, 1 and 3 (each within the scatter of the next); then compound 2.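

In this assay, 4-chlorophenyl carries no hydrogen-bond donor or acceptor, unlike 3-bromo-4-hydroxyphenyl, yet the two groups are not resolved (a 1.3-fold lower number from compound 3 to compound 4 (0.13 log units; within the scatter)), and 4-chlorophenyl is also not resolved from 2,6-dichlorophenyl (a 1.1-fold lower number from compound 1 to compound 4 (0.04 log units; within the scatter)). Across these four compounds, three halogenated aryl groups on the carbon with a double bond to nitrogen therefore read alike, and 2,5-dimethoxyphenyl alone stands apart (a 9.2-fold lower number from compound 2 to compound 4 (0.96 log units; beyond the scatter)). Nothing available explains these steps or the separation of the dimethoxy compound.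

The compounds shown leave open how an unsubstituted phenyl, or an aryl group bearing an amine or a carboxylic acid, would read at this position in this assay. They also leave open whether a single methoxy group would be enough to separate a compound from the halogenated set.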